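The compounds below may be only part of what the source reports. "The series", "measured", "known", "first", "only" and "open" are said of these compounds alone.

Compound 1 `Cc1ncc([N+](=O)[O-])n1CCSC(=S)N1CCC(=O)CC1` is the starting point. In an ADME assay on HeLa cells (Homo sapiens) for cytotoxicity (a lower number here means a stronger inhibitor, a higher number a weaker inhibitor), compound 1 reaches only the limit of the assay, > 1000 ug/mL, so no number is known for it; (the limit of > 1000 ug/mL in this assay, at which 2 of the 3 values shown sit). Compound 2 `Cc1ncc([N+](=O)[O-])n1CCSC(=S)N1CCC(OC(=O)CSC(=S)N2CCCC2)CC1` likewise gives in this assay only the limit > 1000 ug/mL. Compound 3 `Cc1ncc([N+](=O)[O-])n1CCSC(=S)N1C(C)CCCC1C` gives in this assay a measured number, 130 ug/mL. Compound 4 `Cc1ncc([N+](=O)[O-])n1CCSC(=S)N1CCC(C)CC1` differs from compound 1 in one place: 4-methylpiperidin-1-yl in place of 4-oxopiperidin-1-yl on a thiocarbonyl carbon. Among the compounds with values here, no pair of measured compounds shows this change, so its size is open. Within the data shown here, a step toward stronger inhibition is expected, estimated as an at least 2.5-fold lower number from compound 1 to compound 4 (0.39 log units; beyond the scatter), since compound 3, the only compound here with a measured number in this assay, gives 130 ug/mL. Compound 4 is therefore estimated at 400 ug/mL in this assay, with a range from 100 ug/mL to 1000 ug/mL, and a real chance that again only a limit is reported.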

Compound 4, half-maximal inhibitory concentration: 190 ug/mL
Beside the measured number, compound 4's estimate is 2.1-fold (0.32 log units) above it, and the stated range covers the measured number.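

In this assay, putting 4-methylpiperidin-1-yl in place of 4-oxopiperidin-1-yl on a thiocarbonyl carbon gives an at least 5.2-fold lower number from compound 1 to compound 4 (0.72 log units; beyond the scatter). The two groups share the same ring, so this place on the molecule responds to a change at the far end of that ring alone, and not only to a ring with added methyl groups as in compound 3. The true size of the step stays unknown because compound 1 sits at a limit: the limit of > 1000 ug/mL in this assay, at which 2 of the 4 values shown sit.

Going by these compounds, it remains open how an unsubstituted piperidin-1-yl would compare. A 4-aminopiperidin-1-yl, or a longer chain in place of the methyl, is also untested among the compounds shown.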